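A few compounds are considered here, and "the series" means these few. Any claim that something is new, unique, unknown or untested is made for them only; others in the source may bear on it.

Compound 1 `Nc1nc(N2CCN(C(=O)COc3ccc(Cl)cc3)CC2)c2nc(-c3ccc(F)cc3)sc2n1` gives 490 nM in a functional assay on cells (Lymphocyte, Homo sapiens); on this read-out higher numbers stand for weaker inhibition and lower numbers for stronger inhibition.
Compound 2 `Cc1cccc(N2CCN(c3nc(N)nc4sc(-c5ccc(F)cc5)nc34)CC2)c1` reaches only the limit > 10000 nM in this assay; this is a limit of the assay, not a number.
Compound 3 `Nc1nc(N2CCN(C(=O)COc3ccc(Cl)cc3)CC2)c2nc(Cc3ccc(F)cc3)sc2n1` gives 700 nM in this assay.

Among the numbers shown, compound 3 and compound 1 lie within the usual scatter of each other, so neither can be called stronger or weaker than the other; the third value, that of compound 2, is a limit. The step from compound 1 to compound 3 carries a 4-fluorobenzyl in place of a 4-fluorophenyl on an aromatic carbon and reads a 1.4-fold higher number from compound 1 to compound 3 (0.15 log units; within the scatter). Compound 4 `Nc1nc(N2CCN(C(=O)COc3ccc(Cl)cc3)CC2)c2nc(CCc3ccc(F)cc3)sc2n1` is the next compound of this kind: the difference from compound 3 is 4-fluorobenzyl in place of 4-fluorophenyl on a saturated chain carbon bound to an aromatic carbon. It is the same kind of change as the earlier one, cut one bond further out, so the chain between the core and the fluorinated ring grows by one more link. Going by the values given here, the only measured step that bears on it, the one from compound 1 to compound 3, stayed within the scatter. On that basis no step beyond the scatter is expected in this assay for compound 4; the expected step is a 1.3-fold higher number from compound 3 to compound 4 (0.11 log units; within the scatter). Compound 4 is therefore estimated at 900 nM, with a range from 350 nM to 2500 nM.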

Compound 4, half-maximal inhibitory concentration: 4400 nM
The estimate for compound 4 lay 4.9-fold (0.69 log units) below the measured number; measured number above the stated range.
By their numbers in this assay, from the lowest: compounds 1 and 3 (each within the scatter of the next); then compound 4. At a limit, above all of these: compound 2.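

At this place on the core, chain length turns out to matter in this assay: the change from 4-fluorobenzyl to 2-(4-fluorophenyl)ethyl gives a 6.3-fold higher number from compound 3 to compound 4 (0.80 log units; beyond the scatter), and measured against the fluorinated ring sitting directly on the core, the same chain gives a 9.0-fold higher number from compound 1 to compound 4 (0.95 log units; beyond the scatter). The earlier change at this place, from 4-fluorophenyl to 4-fluorobenzyl, gave only a 1.4-fold higher number from compound 1 to compound 3 (0.15 log units; within the scatter), so compounds 1 and 3 alone made this position look indifferent to such a change, whereas compound 4 shows that the indifference ends with the 2-(4-fluorophenyl)ethyl group. What lies behind the weaker inhibition of compound 4 cannot be told, as nothing measured here bears on a cause.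

On these data alone, whether a still longer chain, such as 3-(4-fluorophenyl)propyl, weakens inhibition further remains open, and so does whether the fluorine plays any part, which a plain 2-phenylethyl group would test. Equally open, as far as these compounds go, is whether the chain itself is the problem or the ring at its end, a question that a 2-aminoethyl group, an amine on the same chain without the ring, would help to separate.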